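The source may hold more compounds than are shown below. What is called first, only, known or untested is meant among the compounds shown, and "the series" means these compounds.

Measured so far:
compound 1 `COc1ccc(-c2cc(/N=C3/NC(=O)CS3)cs2)cc1` — in a functional assay on MCF7 cells (Homo sapiens) for cytotoxicity, read by MTT assay, with a stated time of 72 h (on this read-out lower numbers stand for stronger inhibition and higher numbers for weaker inhibition), compound 1 gives a limit, > 50000 nM.
compound 2 `Cc1ccc(/C=C2\S/C(=N\c3csc(-c4ccc(Cl)cc4)c3)NC2=O)cc1` — compound 2 gives 900 nM.
compound 3 `O=C1N/C(=N/c2csc(-c3ccc(Cl)cc3)c2)S/C1=C\c1ccc(Br)cc1` — compound 3 gives 2500 nM.

Of the two numbers, compound 3 holds the higher one; the step of a 2.8-fold higher number from compound 2 to compound 3 (0.44 log units; beyond the scatter) separates it from compound 2. Compound 4 `COc1ccc(/C=C2\S/C(=N\c3csc(-c4ccc(Cl)cc4)c3)NC2=O)cc1OC` arises from compound 3 by 3,4-dimethoxyphenyl in place of 4-bromophenyl on a double-bonded chain carbon bound to a double-bonded ring carbon. Within the data shown here, the single measured step, a 2.8-fold higher number from compound 2 to compound 3 (0.44 log units; beyond the scatter), also swaps the substituent on the aryl group bound to that chain carbon and was modest, so a change on this aryl group appears to move the number only a little. Among the measured compounds shown here, no measured step involves methoxy groups on this ring. Compound 4 is therefore expected to sit near compounds 2 and 3, with an expected step of a 1.7-fold lower number from compound 3 to compound 4 (0.22 log units; within the scatter), giving an estimate of 1500 nM for compound 4, within 400 nM to 6000 nM.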

Compound 4, half-maximal inhibitory concentration: 7600 nM
For compound 4 the middle estimate is 5.1-fold (0.70 log units) below the measured one; measured number outside the range, above it.
By their numbers in this assay, from the lowest: compound 2; then compound 3; then compound 4. At a limit, above all of these: compound 1.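

In this assay the change to 3,4-dimethoxyphenyl gives a 3.0-fold higher number from compound 3 to compound 4 (0.48 log units; beyond the scatter) and also an 8.4-fold higher number from compound 2 to compound 4 (0.93 log units; beyond the scatter) so the aryl group on this chain carbon matters more than the earlier step alone suggested. Among these three compounds with exact numbers, the two methoxy groups go with the highest number, though no measurement shown explains why. Still open, as far as these compounds go, is whether a single methoxy group on this ring would behave the same way, and how a phenyl ring carrying an amine or a carboxylic acid would read here.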